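A few compounds are considered here, and "the series" means these few. Any claim that something is new, unique, unknown or untested is made for them only; others in the source may bear on it.

Going by the values given here, in an ADME assay (liver, Mus musculus) for metabolic stability, read by LC-MS, using microsomes, tested at 1 uM (on this read-out higher numbers stand for a longer-lived compound and lower numbers for a shorter-lived compound), compound 3 (`CCN(CC)CCN/C(C)=N\c1ccnc2cc(Cl)ccc12`) gives 0.3 h as the only true number so far. Compound 1 (`C/C(=N/c1ccnc2cc(Cl)ccc12)NC1CCN(Cc2ccccc2)CC1`) reads > 1 h and this is a limit of the assay, not a number. Compound 2 (`C/C(=N/c1ccnc2cc(Cl)ccc12)NC1CCN(C(C)C)CC1`) reads > 1 h and this too is a limit. Between them lies a step that the two limits leave unreadable from compound 1 to compound 2 with isopropyl in place of benzyl on an amine nitrogen in a ring, so it offers no size to borrow. The change to compound 4 (`C/C(=N/c1ccnc2cc(Cl)ccc12)NC1CCN(C)CC1`) is 1-methylpiperidin-4-yl in place of 2-(diethylamino)ethyl on an amine nitrogen and brings one six-membered non-aromatic ring where 2-(diethylamino)ethyl had none. Among the compounds with values here, compounds 1 and 2 also carry a ring, and the limit of > 1 h in this assay, at which 2 of the 3 values shown sit, is the only guide, so a rise beyond the scatter is expected. The expected size is a 3.3-fold higher number from compound 3 to compound 4 (0.52 log units; beyond the scatter) as an estimate only. Compound 4 is estimated at 1 h (expected range 0.4 h to 2.5 h).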

Compound 4, half-life: > 1 h
Compound 4: a limit, no number; the forecaster's own chance of this, stated with the estimate: 55%; the middle value sits exactly at the limit.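

Going by these compounds alone, on an amine nitrogen, 1-methylpiperidin-4-yl in place of 2-(diethylamino)ethyl gives the first readable step in this assay, an at least 3.3-fold higher number from compound 3 to compound 4 (0.52 log units; beyond the scatter), so a change at this position can move the half-life beyond the scatter. The reading for compound 4 is a limit, not a number. Compound 4 now stands with compounds 1 and 2: the limit of > 1 h in this assay, at which 3 of the 4 values shown sit. From the compounds shown here alone, the steps among compounds 1, 2 and 4 cannot be read, so any order among them stays unknown. Going by these compounds, whether a morpholine ring or a longer chain at this position would read like compound 3 or compound 4 also stays open.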